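Chloro to Cyano on the Fused Ring of Compound 2

This account rests on a few compounds, and the source may have more. Where it says the series, first, only, none or still open, it means among the compounds named here.

Measured compounds:
compound 1, `O=S(=O)(c1ccc(F)cc1)c1cnc2cc(F)ccc2c1-c1ccc(Cl)cc1`: 91.6%
compound 2, `O=S(=O)(c1ccc(F)cc1)c1cnc2cc(Cl)ccc2c1-c1ccc(Cl)cc1`: 92.8%

In an assay on cell membranes for displacement of a labelled ligand from metabotropic glutamate receptor 5 (Rattus norvegicus), with a stated time of 60 min, tested at 1 uM (a lower number here means less inhibition, a higher number more inhibition at the concentration tested (going by the name of the read-out)), compound 1 gives 91.6% and compound 2 gives 92.8%. Compound 2 holds the higher of the two numbers, yet the step of a number 1.2 percentage points higher from compound 1 to compound 2 (within the scatter) lies within the scatter, so the pair cannot be ordered. Compound 3, `N#Cc1ccc2c(-c3ccc(Cl)cc3)c(S(=O)(=O)c3ccc(F)cc3)cnc2c1`, differs from compound 2 by cyano in place of chloro on an aromatic carbon. For the measured compounds named here, the one measured step swaps one halogen for another and says little about a cyano group, so the expected step of a number 8.8 percentage points lower from compound 2 to compound 3 (within the scatter) is a modest drop with wide uncertainty. Compound 3 is expected at 84%, within 60% to 97%.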

Compound 3, a percentage reported as inhibition, at one concentration (the size of the read-out at that concentration, not a potency): 8.7%
Compound 3: the middle estimate sits 75.3 percentage points above what was measured; the measured number lies below the stated range.
By their numbers in this assay, from the lowest: compound 3; then compounds 1 and 2 (each within the scatter of the next).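

In this assay, this aromatic carbon proves far less permissive than the two halogens suggested, since cyano in place of chloro gives a number 84.1 percentage points lower from compound 2 to compound 3 (beyond the scatter) and cyano in place of fluoro gives a number 82.9 percentage points lower from compound 1 to compound 3 (beyond the scatter). The two steps agree in direction and size, so the fall does not hang on which halogen cyano replaces. No available evidence bears on what lies behind this fall.

As far as these compounds go, whether the loss is particular to cyano remains open. The compounds shown do not tell how a methoxy group, an amine or a carboxylic acid would read at this carbon.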